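Notes on methylating the amide nitrogen of compound 2

The source may hold more compounds than are shown below. What is called first, only, known or untested is meant among the compounds shown, and "the series" means these compounds.

Compound 1 `COc1ccc(CNC(=O)c2nn(-c3ccc(F)cc3)c(OC[C@@H](O)C[C@@H](O)CC(=O)O)c2C(C)C)cc1` and compound 2 `COc1cccc(CNC(=O)c2nn(-c3ccc(F)cc3)c(OC[C@@H](O)C[C@@H](O)CC(=O)O)c2C(C)C)c1` share one core and differ only in the methoxyphenyl group on a saturated chain carbon bound to an amide-type nitrogen. Among the measured compounds shown here, in an assay on microsomes from liver for inhibition of 3-hydroxy-3-methylglutaryl-coenzyme A reductase (Rattus norvegicus) (a higher number here means a weaker inhibitor, a lower number a stronger inhibitor), compound 1 gives 12 nM and compound 2 gives 16 nM; the step of a 1.3-fold higher number from compound 1 to compound 2 (0.12 log units; within the scatter) lies within the scatter, so compound 2 stands level with compound 1 on the two numbers so far. Compound 3 `COc1cccc(CN(C)C(=O)c2nn(-c3ccc(F)cc3)c(OC[C@@H](O)C[C@@H](O)CC(=O)O)c2C(C)C)c1` carries methyl in place of hydrogen on an amide-type nitrogen. For the measured compounds named here, no measured step touches this nitrogen; the only step known changes the methoxyphenyl group and is small, so it carries no information about the change at hand. Going by the values given here, with no precedent, the step to compound 3 is expected to be modest and, if anything, toward a higher number, estimated at a 1.9-fold higher number from compound 2 to compound 3 (0.27 log units; within the scatter). Compound 3 is therefore expected to give about 30 nM in this assay, with a range of 8 nM to 120 nM.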

Compound 3, half-maximal inhibitory concentration: 21 nM
The estimate for compound 3 lay 1.4-fold (0.15 log units) above the measured number; the measured number falls inside the stated range.
By their numbers in this assay, from the lowest: compounds 1, 2 and 3 (each within the scatter of the next).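

In this assay, among the compounds shown here, methyl can replace the amide hydrogen of compound 2 with a 1.3-fold higher number from compound 2 to compound 3 (0.12 log units; within the scatter), the first reading at this amide-type nitrogen; in this pair, the hydrogen on that nitrogen is not needed to stay in this range of numbers. The change from (4-methoxybenzyl)amino to (3-methoxybenzyl)(methyl)amino, which alters the methoxyphenyl group and this nitrogen together, gives a 1.8-fold higher number from compound 1 to compound 3 (0.24 log units; within the scatter), so this combined change also stays within the scatter. Nothing available explains this result.

On these data alone, it remains open whether an ethyl group, a longer chain or a chain ending in a carboxylic acid would be accommodated on this nitrogen as methyl is here. Also open, as far as these compounds go, is whether the methyl step would read the same with 4-methoxyphenyl in place of 3-methoxyphenyl.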